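Replacing the Amine Side Chain with a Carboxylic Acid

This account rests on a few compounds, and the source may have more. Where it says the series, first, only, none or still open, it means among the compounds named here.

Compound 1 `CC(C)[C@H](NC(=O)c1ccc(Cl)c(Cl)c1)C(=O)N[C@H]1CCN(Cc2ccc(OCCCN(C)C)cc2)C1`: 794 nM
Compound 2 `CN(C)CCCOc1ccc(CN2CC[C@H](NC(=O)[C@H](CCCN)NC(=O)c3ccc(Cl)c(Cl)c3)C2)cc1`: < 10000 nM

Of the compounds shown here, two share a core and have been tested in an assay on HEK293 cells for binding affinity to Urotensin-2 receptor (Homo sapiens), read by radioligand binding; on this read-out lower numbers stand for stronger inhibition and higher numbers for weaker inhibition. Compound 1 gives 794 nM. Compound 2 reaches only a limit of the assay, < 10000 nM. Within the data shown here, the one step between them, a step that the limit leaves unreadable from compound 1 to compound 2, therefore cannot be read, because the limit of < 10000 nM in this assay, at which 1 of the 2 values shown sits, hides its size. Compound 3 `CN(C)CCCOc1ccc(CN2CC[C@H](NC(=O)[C@H](CCC(=O)O)NC(=O)c3ccc(Cl)c(Cl)c3)C2)cc1` is the next member. It differs from compound 2 by carboxy in place of aminomethyl on a saturated chain carbon, three bonds along the chain from an amide-type nitrogen and a carbonyl carbon. Among the measured compounds shown here, no measured step bears on this kind of change, and compound 2 itself is known only as a limit, so the expectation rests on compound 1 alone and is wide. Compound 3 is expected to give about 3000 nM, somewhere between 300 nM and 30000 nM. The step this estimate implies is a step that the limit leaves unreadable from compound 2 to compound 3, with no direction claimed beyond the scatter.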

Compound 3, inhibition constant: < 10000 nM
Compound 3 was reported as a limit; the forecaster's own chance of this, stated with the estimate: 40%; the middle value lies beyond the limit too.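

Compound 3, like compound 2, is known only as a limit, so the steps from compound 1 to compound 3 and from compound 2 to compound 3 cannot be read: the limit of < 10000 nM in this assay, at which 2 of the 3 values shown sit. From the compounds shown here alone, how strongly compound 2 and compound 3 actually bind the receptor remains open, and so does which of the two binds more strongly.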